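Amide side-chain variation on the shared bis-indolyl core

A few compounds are considered here, and "the series" means these few. Any claim that something is new, unique, unknown or untested is made for them only; others in the source may bear on it.

Measured in a functional assay on BGC-823 cells (Homo sapiens) for cytotoxicity, read by MTT assay, with a stated time of 24 h; on this read-out higher numbers stand for weaker inhibition and lower numbers for stronger inhibition:
compound 1, `CC[C@H](C)[C@@H](NC(=O)Cn1cc(C2=C(c3c[nH]c4ccccc34)C(=O)N(C)C2=O)c2ccccc21)C(=O)OC`: > 100000 nM
compound 2, `COC(=O)C[C@@H](NC(=O)Cn1cc(C2=C(c3c[nH]c4ccccc34)C(=O)N(C)C2=O)c2ccccc21)C(=O)OC`: 24600 nM

Among the measured compounds shown here, compound 2 holds the only number in this assay. The value of compound 1 is a limit of the assay, not a number (the limit of > 100000 nM in this assay, at which 1 of the 2 values shown sits). For the measured compounds named here, the one measured step is an at least 4.0-fold lower number from compound 1 to compound 2 (0.60 log units; beyond the scatter).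

Compound 3, `COC(=O)[C@@H](CO)NC(=O)Cn1cc(C2=C(c3c[nH]c4ccccc34)C(=O)N(C)C2=O)c2ccccc21`, differs from compound 2 by hydroxy in place of methoxycarbonyl on a saturated chain carbon, two bonds along the chain from an amide-type nitrogen and a carbonyl carbon. Going by the values given here, the only measured step exchanges sec-butyl for (methoxycarbonyl)methyl on a saturated chain carbon bound to an amide-type nitrogen and a carbonyl carbon, a different group at a different place, and its size is known only as a lower bound, so it does not bear directly on the hydroxy for methoxycarbonyl exchange. Among the compounds with values here, no measured step speaks to this change, so no step beyond the scatter is expected in this assay. Compound 3 is expected to give 30000 nM, range 9000 nM to 100000 nM, which is estimated as a 1.2-fold higher number from compound 2 to compound 3 (0.09 log units; within the scatter).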

Compound 3, half-maximal inhibitory concentration: 28900 nM
Compound 3: middle estimate off by 1.0-fold (0.02 log units), on the high side; low and high end bracket the measured number.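

In this assay, hydroxy in place of methoxycarbonyl on a saturated chain carbon, two bonds along the chain from an amide-type nitrogen and a carbonyl carbon, gives a 1.2-fold higher number from compound 2 to compound 3 (0.07 log units; within the scatter), so on this read-out the methoxycarbonyl is not needed at this place. The value of compound 1 is a limit and not a number: the limit of > 100000 nM in this assay, at which 1 of the 3 values shown sits. Hydroxymethyl in place of sec-butyl gives an at least 3.4-fold lower number from compound 1 to compound 3 (0.53 log units; beyond the scatter), so two different chains, (methoxycarbonyl)methyl and hydroxymethyl, now both stand apart from sec-butyl.

Open, as far as these compounds go, is how an amine or a carboxylic acid in place of the hydroxy would read in this assay, and whether a longer chain carrying the hydroxy would move the number. Also open, from the compounds shown here alone, is the full size of both steps from compound 1, since only a lower bound is available for them.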